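Aryl amine variation on the shared core

The compounds below may be only part of what the source reports. "The series", "measured", "known", "first", "only" and "open" are said of these compounds alone.

Going by the values given here, compound 3 `O=C1C(Nc2ccccc2F)=CC(=O)c2c1nc1n2[C@H]2OC[C@@H](O)[C@H]2OC1` is the one member that returns a number in a functional assay on MGC-803 cells (Homo sapiens) for inhibition, read by sulforhodamine B assay; a higher number here means a weaker inhibitor, a lower number a stronger inhibitor: compound 3 gives 2000 nM. Compound 1 `O=C1C(N2CCCCC2)=CC(=O)c2c1nc1n2[C@H]2OC[C@@H](O)[C@H]2OC1` reaches only a limit in this assay, > 4000 nM. Compound 2 `O=C1C(NC2CCCC2)=CC(=O)c2c1nc1n2[C@H]2OC[C@@H](O)[C@H]2OC1` likewise stops at a limit, > 16000 nM. The step of an at least 8.0-fold lower number from compound 2 to compound 3 (0.90 log units; beyond the scatter) and the step of an at least 2.0-fold lower number from compound 1 to compound 3 (0.30 log units; that floor lies within the scatter) both favour the arylamine over the saturated amines, while a step that the two limits leave unreadable from compound 1 to compound 2. Compound 4 `O=C1C(Nc2ccc(I)cc2)=CC(=O)c2c1nc1n2[C@H]2OC[C@@H](O)[C@H]2OC1` keeps the arylamine and changes only the aryl: 4-iodophenyl in place of 2-fluorophenyl on an amine nitrogen. Among the compounds with values here, no measured step compares one aryl with another, so no step bears directly on this change. The expected step is no change at the digits printed from compound 3 to compound 4 (within the scatter), within the scatter. Compound 4 is therefore estimated at 2000 nM, between 700 nM and 6000 nM.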

Compound 4, half-maximal inhibitory concentration: 2150 nM
Beside the measured number, compound 4's estimate is 1.1-fold (0.03 log units) below it; low and high end bracket the measured number.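

Putting 4-iodophenyl in place of 2-fluorophenyl on the amine nitrogen gives a 1.1-fold higher number from compound 3 to compound 4 (0.03 log units; within the scatter) in this assay, so this one aryl-to-aryl comparison shows no readable effect of the change. The arylamine keeps its edge over the cyclopentylamino compound with this second aryl, with an at least 7.4-fold lower number from compound 2 to compound 4 (0.87 log units; beyond the scatter), a floor set by a limit: the limit of > 16000 nM in this assay, at which 1 of the 4 values shown sits.
Against the piperidin-1-yl compound the result is an at least 1.8-fold lower number from compound 1 to compound 4 (0.26 log units; that floor lies within the scatter), also a floor set by a limit: the limit of > 4000 nM in this assay, at which 1 of the 4 values shown sits.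

Compounds 3 and 4 change the halogen and its place together, so the two remain unseparated. An aryl carrying a carboxylic acid or a dimethylamino group would show whether anything other than a halogen on the ring moves the number.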